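The compounds below may be only part of what the source reports. "The series", "measured", "known", "first", "only" and "open" are said of these compounds alone.

Working notes on the series.

Compound 1, `O=C1C(=O)N(CN2CCN(c3ccnc4cc(C(F)(F)F)ccc34)CC2)c2cccc(Cl)c21`, gives 28400 nM in a functional assay on MDA-MB-468 cells (Homo sapiens) for cytotoxicity, read by sulforhodamine B assay, with a stated time of 48 h; on this read-out lower numbers stand for stronger inhibition of growth and higher numbers for weaker inhibition of growth. Compound 2, `O=C1C(=O)N(CN2CCN(c3ccnc4cc(C(F)(F)F)ccc34)CC2)c2cccc(Br)c21`, gives 52200 nM in this assay. The one change between them is bromo in place of chloro on an aromatic carbon
and the step it made was a 1.8-fold higher number from compound 1 to compound 2 (0.26 log units; within the scatter).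

Compound 3, `NC(=S)N/N=C1/C(=O)N(CN2CCN(c3ccnc4cc(Cl)ccc34)CC2)c2cc(Cl)ccc21`, carries a different core; the difference between the two cores is not broken down here. In this assay compound 3 gives 26500 nM, which sits within the scatter of compound 1 and of compound 2.

Compound 4, `NC(=S)N/N=C1/C(=O)N(CN2CCN(c3ccnc4cc(Cl)ccc34)CC2)c2cc(Br)ccc21`, is still to be measured in this assay. Its change from compound 3 is bromo in place of chloro on an aromatic carbon
This is the same kind of change as that from compound 1 to compound 2, not the same: there the place was ortho to a fused ring and meta to a fused ring, here it is meta to a fused ring and para to a fused ring.

Because a 1.8-fold higher number from compound 1 to compound 2 (0.26 log units; within the scatter) stayed within the scatter, the step from compound 3 to compound 4 is expected to be small as well, about a 1.4-fold higher number from compound 3 to compound 4 (0.16 log units; within the scatter). Compound 4 is therefore estimated at 38000 nM, with a likely range from 18000 nM to 80000 nM.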

Compound 4, concentration for 50% growth inhibition: 11200 nM
Compound 4: the middle estimate sits 3.4-fold (0.53 log units) above what was measured, and the stated range ends above it.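

Bromo in place of chloro on an aromatic carbon gives a 2.4-fold lower number from compound 3 to compound 4 (0.37 log units; beyond the scatter) in this assay, a modest step that lies beyond the scatter. The same change does not carry over as one fixed step from the core of compound 1 to the core of compound 3, and the size of the step depends on the pair in which it is read: the same change on two cores in this assay, a 1.8-fold higher number (0.26 log units; within the scatter) from compound 1 to compound 2 and a 2.4-fold lower number (0.37 log units; beyond the scatter) from compound 3 to compound 4, 4.3-fold (0.64 log units) apart, beyond the scatter of two such steps

This does not show what lies behind the gap, as the two pairs differ both in the core and in the place of the halogen on the ring, and two pairs give no rule for the series.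

Still open, from the compounds shown here alone, is whether bromo in place of chloro on the core of compound 1, at the place it holds in compound 4, would repeat the step seen on the core of compound 3. Also open, going by these compounds, is how an amine or a methoxy group at that place on the core of compound 3 would compare with chloro and bromo.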